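A few compounds are considered here, and "the series" means these few. Any claim that something is new, unique, unknown or untested is made for them only; others in the source may bear on it.

Within the data shown here, in a functional assay on KB cells (Homo sapiens) for inhibition, read by sulforhodamine B assay (a higher number here means a weaker inhibitor of growth, a lower number a stronger inhibitor of growth), only two compounds have been measured so far. Compound 1 (`COc1cc(-c2ccc(-c3ccc(-c4nc5cc(C)ccc5[nH]4)cc3)cc2)cc(OC)c1OC`) gives 2110 nM. Compound 2 (`Fc1ccc(-c2ccc(-c3ccc(-c4nc5ccccc5[nH]4)cc3)cc2)cc1`) gives 41300 nM, the higher of the two numbers and so the weaker inhibitor of growth, and the gap between the two lies beyond the scatter. The next compound to be tested, compound 3 (`Clc1cccc(-c2ccc(-c3ccc(-c4nc5ccccc5[nH]4)cc3)cc2)c1`), has 3-chlorophenyl in place of 4-fluorophenyl on an aromatic carbon, para to a large group: 3-chlorophenyl in place of 4-fluorophenyl on an aromatic carbon. Among the measured compounds shown here, no measured pair isolates this change, because compound 1 and compound 2 differ in more than one place, so the data offer no direct guide to its size. The rest of the structure stays as it is in compound 2, so no step beyond the scatter is expected in this assay, with a slightly lower number the likelier direction. The expected change is a 1.4-fold lower number from compound 2 to compound 3 (0.14 log units; within the scatter). Compound 3 is estimated at 30000 nM, with an expected range of 10000 nM to 70000 nM.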

Compound 3, concentration for 50% growth inhibition: 32300 nM
For compound 3 the middle estimate is 1.1-fold (0.03 log units) below the measured one; low and high end bracket the measured number.
By their numbers in this assay, from the lowest: compound 1; then compounds 3 and 2 (each within the scatter of the next).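

In this assay, among these compounds, the exchange of 4-fluorophenyl for 3-chlorophenyl on an aromatic carbon, para to a large group, gives the first step that can be read at this place: a 1.3-fold lower number from compound 2 to compound 3 (0.11 log units; within the scatter). This step lies within the scatter, so this exchange does not separate the two compounds, and the place tolerates it without a measurable shift in this assay. Among the compounds shown here, the exchange alters both the halogen and where it sits on the phenyl ring, so the single step cannot show what either alteration does alone, and no measurement of any property of these groups is available to account for the result.

Compound 1 differs from compound 2 and from compound 3 in more than one place, so those steps cannot be read, and what lies behind the value of compound 1, 2110 nM, remains open. Also open, from the compounds shown here alone, is how this assay would respond to a plain phenyl, a methoxyphenyl, or a phenyl carrying an amine or a carboxylic acid at this same place.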